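The compounds below may be only part of what the source reports. "The series", "measured", "known", "first", "only" and "open" are said of these compounds alone.

Of the compounds shown here, three with one shared core have been measured in a functional assay on HCT-116 cells (Homo sapiens) for inhibition, read by MTT assay, with a stated time of 48 h; on this read-out higher numbers stand for weaker inhibition and lower numbers for stronger inhibition. There compound 1 (`COc1ccc(N(C)c2nc(C)nc3ccccc23)cc1C(=O)OCC[Se]C#N`) gives 951 nM and compound 2 (`COc1ccc(N(C)c2nc(C)nc3ccccc23)cc1C(=O)OCCCC[Se]C#N`) gives 662 nM while compound 3 (`COc1ccc(N(C)c2nc(C)nc3ccccc23)cc1OCCCC[Se]C#N`) gives 512 nM on the same read-out. Compound 3 therefore lies within the scatter of both others, and the three cannot be ranked.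

Compound 4 (`COc1ccc(N(C)c2nc(C)nc3ccccc23)cc1[Se]C#N`) is still unmeasured. It differs from compound 3 by a group of 3 heavy atoms (1 carbon, 1 nitrogen, 1 selenium; no ring) in place of a group of 8 heavy atoms (5 carbon, 1 nitrogen, 1 oxygen, 1 selenium; no ring), on an aromatic carbon and the exchange sits ortho to a methoxy group and meta to a large group.

Two measured steps alter the group on this aromatic carbon: a 1.9-fold lower number from compound 1 to compound 3 (0.27 log units; within the scatter) and a 1.3-fold lower number from compound 2 to compound 3 (0.11 log units; within the scatter) are the closest precedents. A third, a 1.4-fold lower number from compound 1 to compound 2 (0.16 log units; within the scatter) changes only the chain. Within the data shown here, none of the measured compounds carries the smaller entering group, so the data offer no direct precedent and the expectation is an extrapolation. With all three steps inside the scatter, no step beyond it is expected, and no direction is firmly indicated. The expected outcome is a 1.2-fold higher number from compound 3 to compound 4 (0.07 log units; within the scatter) in this assay with wide uncertainty. Compound 4 is estimated at 600 nM with an expected range from 200 nM to 1800 nM in this measurement.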

Compound 4, half-maximal inhibitory concentration: 34 nM
Compound 4: the middle estimate sits 18-fold (1.25 log units) above what was measured; the whole stated range lies above it.
By their numbers in this assay, from the lowest: compound 4; then compounds 3, 2 and 1 (each within the scatter of the next).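

Among the earlier compounds, every change at this aromatic carbon, ortho to a methoxy group and meta to a large group, stayed within the scatter in this assay, but the group of 3 heavy atoms breaks that flat picture, with a 15-fold lower number from compound 3 to compound 4 (1.18 log units; beyond the scatter), a 19-fold lower number from compound 2 to compound 4 (1.29 log units; beyond the scatter) and a 28-fold lower number from compound 1 to compound 4 (1.45 log units; beyond the scatter). The three larger groups, whether ester-linked or ether-linked and whatever their chain length, cannot be told apart, so among these four compounds the sharp difference appears only with the group that carries no chain. All four compounds contain the selenium and the nitrile, so the presence of these atoms alone does not separate compound 4 from the others, and no measurement bears on why the change is so large.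

The compounds shown leave open whether a methylene linker would keep the number near that of compound 4 or return it to the level of compound 3. Also open, from the compounds shown here alone, is whether a sulfur atom in place of the selenium, or a methyl group in place of the nitrile, would preserve the value of compound 4.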